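Removing one methoxy group from compound 2

The source may report more compounds than this note shows. Statements on the series, on what has been measured and on what is new or still open speak of the compounds shown alone.

Compound 2 `COc1cc(-c2cc(/C=C/C(=O)c3ccc(N)cc3)[nH]n2)cc(OC)c1OC` is measured in a functional assay on NCI-H23 cells (Homo sapiens) for cytotoxicity, read by sulforhodamine B assay, with a stated time of 48 h, tested at 0.01 uM (on this read-out higher numbers stand for a weaker effect at the one concentration tested and lower numbers for a stronger effect), where compound 2 gives 102%. Compound 3 `COc1ccc(C(=O)/C=C/c2cc(-c3cc(OC)c(OC)c(OC)c3)n[nH]2)cc1OC` gives 93% and compound 1 `COc1ccc(-c2cc(/C=C/C(=O)c3ccc(N)cc3)[nH]n2)cc1` gives 92%, both within the scatter of compound 2. Compound 4 `COc1ccc(-c2cc(/C=C/C(=O)c3ccc(N)cc3)[nH]n2)cc1OC` differs from compound 2 by hydrogen in place of methoxy on an aromatic carbon. No measured step touches this position; the only step shown, a number 9 percentage points lower from compound 2 to compound 3 (within the scatter), changes the group on the carbonyl carbon instead and stays within the scatter, so the three compounds give no reason to expect a change beyond the scatter here. Compound 4 is therefore expected to give about 95%, with a range from 80% to 105%, so that the estimated step of a number 7 percentage points lower from compound 2 to compound 4 (within the scatter) is within the scatter.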

Compound 4, a percentage reported as activity, at one concentration (the size of the read-out at that concentration, not a potency): 103%
Beside the measured number, compound 4's estimate is 8 percentage points below it; measured number inside the range.
By their numbers in this assay, from the lowest: compounds 1, 3, 2 and 4 (each within the scatter of the next, the first and the last beyond it).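

In this assay, hydrogen in place of methoxy on this aromatic carbon gives a number 1 percentage points higher from compound 2 to compound 4 (within the scatter), so losing this methoxy group from compound 2 leaves the number unchanged within the scatter. Adding a methoxy group to compound 1 on an aromatic carbon ortho to a methoxy group gives a number 11 percentage points higher from compound 1 to compound 4 (beyond the scatter), a modest step towards a weaker effect at the one concentration tested. On these data alone, whether an amine, a hydroxyl group or an ethoxy group on this carbon would move the number remains open. Nothing available explains either step.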